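A few compounds are considered here, and "the series" means these few. Any claim that something is new, unique, unknown or untested is made for them only; others in the source may bear on it.

Working notes on the series. The three measured compounds share one core and differ only in the aryl group on the carbon of that core. Compound 1 `O=S(=O)(c1ccc(F)c(F)c1)c1cnc2c(F)cccc2c1-c1ccccc1F` gives 1.39 mL/min in an ADME assay on microsomes from liver (Homo sapiens) for metabolic stability, tested at 2.5 uM; a lower number here means slower removal, a higher number faster removal of the compound. Compound 2 `O=S(=O)(c1ccc(F)c(F)c1)c1cnc2c(F)cccc2c1-c1cccc(F)c1` gives 1.28 mL/min. Compound 3 `O=S(=O)(c1ccc(F)c(F)c1)c1cnc2c(F)cccc2c1-c1cccc(Cl)c1` gives 1.13 mL/min, the lowest of the three numbers, though the steps to the other two, a 1.2-fold lower number from compound 1 to compound 3 (0.09 log units; within the scatter) and a 1.1-fold lower number from compound 2 to compound 3 (0.05 log units; within the scatter), are both within the scatter, as is a 1.1-fold lower number from compound 1 to compound 2 (0.04 log units; within the scatter). Compound 3 therefore stands level with compounds 1 and 2 in this assay.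

Compound 4 `Cc1ccc(S(=O)(=O)c2cnc3c(F)cccc3c2-c2cccc(Cl)c2)cc1F` has not been measured. It differs from compound 3 by methyl in place of fluoro on an aromatic carbon, on the sulfonyl-bearing ring; the change is ortho to a fluoro group and para to a large group. Going by the values given here, no measured step touches that ring. The nearest comparison, a 1.1-fold lower number from compound 2 to compound 3 (0.05 log units; within the scatter), exchanges one substituent for another on an aromatic carbon and stays within the scatter, as do the other two steps. The expectation for compound 4 is thus no step beyond the scatter, a 1.2-fold higher number from compound 3 to compound 4 (0.06 log units; within the scatter). Compound 4 is estimated at 1.3 mL/min, range 0.7 mL/min to 2.6 mL/min.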

Compound 4, intrinsic clearance in a liver preparation (reported as CLH), per the amount of preparation that the assay uses: 3.18 mL/min
The estimate for compound 4 lay 2.4-fold (0.39 log units) below the measured number; measured number above the stated range.
By their numbers in this assay, from the lowest: compounds 3, 2 and 1 (each within the scatter of the next); then compound 4.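

Methyl in place of fluoro, on the aromatic carbon ortho to a fluoro group and para to a large group, gives a 2.8-fold higher number from compound 3 to compound 4 (0.45 log units; beyond the scatter) in this assay. The aryl changes among compound 1, compound 2 and compound 3 all stay within the scatter, so this position on the sulfonyl-bearing ring is the only place among the compounds shown where a single change moves the number beyond it. The data shown offer no measured account of this rise.

From the compounds shown here alone, it remains open whether the rise belongs to the entering methyl or to the departing fluoro, and how a methoxy group, an ethyl group or a chloro group at the same carbon would read in this assay. Also open, going by these compounds, is whether the same exchange gives a similar step alongside the aryl groups of compound 1 and compound 2.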